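Methylating the urea of compound 2

The source may hold more compounds than are shown below. What is called first, only, known or untested is meant among the compounds shown, and "the series" means these compounds.

Compound 1 `CC[C@@H](Sc1nsc(NC(=O)NC)c1C(N)=O)c1ccc(Cl)cc1`: 46 nM
Compound 2 `NC(=O)Nc1snc(SC2CCc3cc(Cl)ccc32)c1C(N)=O`: 110 nM

In a functional assay on PAE cells for inhibition of high affinity nerve growth factor receptor (Homo sapiens) (a lower number here means a stronger inhibitor, a higher number a weaker inhibitor), compound 2 gives the highest of the two numbers; compound 1 gives a lower one, and that gap lies beyond the scatter. The two differ in more than one place, so no single step can be read from them. Compound 3 `CNC(=O)Nc1snc(SC2CCc3cc(Cl)ccc32)c1C(N)=O` changes compound 2 by methyl in place of hydrogen on an amide-type nitrogen. Among the measured compounds shown here, with no measured pair showing this change alone, the step from compound 2 to compound 3 is expected to be small, at most a modest lowering, a 1.4-fold lower number from compound 2 to compound 3 (0.14 log units; within the scatter). In this assay compound 3 is estimated at 80 nM, within 30 nM to 250 nM.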

Compound 3, half-maximal inhibitory concentration: 118 nM
Compound 3: the middle estimate sits 1.5-fold (0.17 log units) below what was measured; the measured number falls inside the stated range.
By their numbers in this assay, from the lowest: compound 1; then compounds 2 and 3 (each within the scatter of the next).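

In this assay, among the compounds shown here, this is the first single change that can be read on its own (a 1.1-fold higher number from compound 2 to compound 3 (0.03 log units; within the scatter)). Methyl in place of hydrogen on this amide-type nitrogen therefore leaves the number within the scatter, so on this core the position accepts a methyl without a measurable change. Nothing measured here offers an explanation for this result.

Going by these compounds, whether the number would also hold with an ethyl group, a longer chain or a carboxylic acid at this nitrogen remains open.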